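A Fluorine Added to the Benzamide Tail

The compounds below may be only part of what the source reports. "The series", "measured", "known", "first", "only" and "open" are said of these compounds alone.

Three measured compounds share one core and differ only in the chain and end group hanging from the aminopyridine. Compound 1 `COc1cccc(-c2nn(-c3ccccc3)cc2-c2ccnc(NCCNC(=O)Nc3cccc(C(F)(F)F)c3)c2)c1` ends in a phenylurea bearing a trifluoromethyl group, compound 2 `COc1cccc(-c2nn(-c3ccccc3)cc2-c2ccnc(NCCCNC(=O)Nc3ccc(Cl)c(Cl)c3)c2)c1` in a dichlorophenylurea, and compound 3 `O=C(NCCCNc1cc(-c2cn(-c3ccccc3)nc2-c2cccc(O)c2)ccn1)c1ccccc1` in a benzamide. In a functional assay on K562 cells (Homo sapiens) for cytotoxicity (on this read-out higher numbers stand for lower toxicity in this test and lower numbers for higher toxicity in this test), compound 1 gives 100000 nM, compound 2 gives 100000 nM, and compound 3 gives 100000 nM. Compound 3 thus stands level with compounds 1 and 2 at the digits shown; its gap to compound 1 and its gap to compound 2 both lie within the usual scatter, so nothing separates the three on this read-out.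

Compound 4 `O=C(NCCCNc1cc(-c2cn(-c3ccccc3)nc2-c2cccc(O)c2)ccn1)c1ccc(F)cc1` is compound 3 with a single change: fluoro in place of hydrogen on an aromatic carbon, so that the benzoyl group becomes (4-fluorophenyl)carbonyl. For the measured compounds named here, no pair of measured compounds isolates this change, so no measured step guides it. Compounds 1, 2 and 3, with very different tails, all sit at the same level in this assay, which makes a single fluoro on the outermost ring unlikely to move the number beyond the scatter. Compound 4 is expected to give about 100000 nM, between 40000 nM and 100000 nM. The expected step of no change at the digits printed from compound 3 to compound 4 (within the scatter) is accordingly none beyond the scatter.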

Compound 4, concentration lethal to 50% of the cells: 100000 nM
Compound 4: middle estimate and measured number agree at the digits printed, within the range that was stated.
By their numbers in this assay, from the lowest: compounds 1, 2, 3 and 4 (each within the scatter of the next).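

In this assay, for the compounds shown here, the swap of hydrogen for fluoro on an aromatic carbon, para to a large group, gives no change at the digits printed from compound 3 to compound 4 (within the scatter) and is the only comparison here between compounds that differ in one place. Compounds 1, 2 and 3 differ from one another in more than one place, so their matching values could not show what any single position does, whereas this pair shows that going from phenyl to 4-fluorophenyl in the benzamide tail leaves the read-out unmoved. No supporting measurement is available to explain this outcome.

Going by these compounds, one small atom at one carbon of this ring says little about the position as a whole, so it remains open whether an amine, a carboxylic acid or a nitrile on that same carbon would leave the number just as level. On these data alone, it also remains open whether fluoro on a different carbon of the ring, or a longer chain between the aminopyridine and the benzamide, would give a value beyond the scatter.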